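The compounds below may be only part of what the source reports. "The series", "measured", "known", "first", "only" and "open" are said of these compounds alone.

The measured compounds:

Compound 1, `CCCCCCc1cc2cn([C@H]3C[C@H](O)[C@@H](CO)O3)c(=O)nc2o1`, in a functional assay on HEL cells (Homo sapiens) for cytotoxicity, read by microscopy (a higher number here means that more compound is tolerated, a lower number that less compound is tolerated), gives the limit > 50000 nM.
Compound 2, `C=CCCCCCCCCc1cc2cn([C@H]3C[C@H](O)[C@@H](CO)O3)c(=O)nc2o1`, gives the limit > 50000 nM in this assay.

Both values are limits of this assay, not numbers, so compound 2 stands only at the upper edge of what was tested, and the step that the two limits leave unreadable from compound 1 to compound 2 cannot be read; the evidence is the limit of > 50000 nM in this assay, at which 2 of the 2 values shown sit. The next compound, compound 3, `C#CCCCCCc1cc2cn([C@H]3C[C@H](O)[C@@H](CO)O3)c(=O)nc2o1`, differs from compound 2 by ethynyl in place of pent-4-en-1-yl on a saturated chain carbon, five bonds along the chain from an aromatic carbon. For the measured compounds named here, no measured step bears on this change, since the only step recorded is hidden by limits. With nothing to point in either direction, the step that the limit leaves unreadable from compound 2 to compound 3 is expected to stay within the scatter. Compound 3 is therefore estimated at 60000 nM in this assay, in the range 25000 nM to 200000 nM, most likely again reported only as a limit.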

Compound 3, minimum cytotoxic concentration: > 200000 nM
Compound 3 ended at the assay's limit; the forecaster's own chance of this, stated with the estimate: 85%; middle value at least 3.3-fold (0.52 log units) away from the limit.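

For the compounds shown here, all the values in this assay are limits, not numbers, so no step among compound 1, compound 2 and compound 3 can be read. The compounds shown leave open whether, and at what concentration, any of the three harms these cells.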